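The source may hold more compounds than are shown below. What is called first, only, known or untested is meant among the compounds shown, and "the series" means these compounds.

Measured so far:
compound 1, `CC(C(=O)NCc1ccc(C(C)(C)C)nc1N1CCCCCC1)c1ccc(NS(C)(=O)=O)c(F)c1`, 0.9 nM
compound 2, `CC(C)Oc1nc(C(C)(C)C)ccc1CNC(=O)C(C)c1ccc(NS(C)(=O)=O)c(F)c1`, 2.3 nM

Both were tested in an assay on cells for antagonist activity at transient receptor potential cation channel subfamily V member 1 (Homo sapiens), read by FLIPR and calcium flux, with a stated time of 6 min; on this read-out lower numbers stand for stronger inhibition and higher numbers for weaker inhibition. For the measured compounds named here, compound 1 holds the lower of the two numbers; the only other number is reached by a 2.6-fold higher number from compound 1 to compound 2 (0.41 log units; beyond the scatter). Compound 3, `CCCCSc1nc(C(C)(C)C)ccc1CNC(=O)C(C)c1ccc(NS(C)(=O)=O)c(F)c1`, has not yet been measured. It differs from compound 1 in one place: butylsulfanyl in place of azepan-1-yl on an aromatic carbon. Going by the values given here, the one measured step that bears on this is the step from compound 1 to compound 2, where azepan-1-yl also left and the number rose modestly. A similar modest rise is expected here, a 2.2-fold higher number from compound 1 to compound 3 (0.35 log units; beyond the scatter), so compound 3 is estimated at 2 nM with a range of 0.7 nM to 6 nM.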

Compound 3, inhibition constant: 3.2 nM
Estimate against measurement, compound 3: 1.6-fold (0.20 log units) below; measured number inside the range.
By their numbers in this assay, from the lowest: compound 1; then compounds 2 and 3 (each within the scatter of the next).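

In this assay, butylsulfanyl, like isopropoxy, falls short of azepan-1-yl on this aromatic carbon, with a 3.6-fold higher number from compound 1 to compound 3 (0.55 log units; beyond the scatter). The two open-chain groups cannot be told apart, despite their different linking atoms and sizes, with a 1.4-fold higher number from compound 2 to compound 3 (0.14 log units; within the scatter). No measurement shown gives a cause for these numbers.

From the compounds shown here alone, what stays open is whether azepan-1-yl owes its edge to its ring or to its nitrogen. A smaller cyclic amine such as pyrrolidin-1-yl and an open-chain amine such as diethylamino would help separate those two features.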